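Swapping fluoro for hydroxy on the hydrazone aryl ring

The compounds below may be only part of what the source reports. "The series", "measured", "known", "first", "only" and "open" are said of these compounds alone.

The measured compounds and their numbers in a functional assay on SW 1116 cells (Homo sapiens) for cytotoxicity, read by MTT assay, with a stated time of 48 h; on this read-out lower numbers stand for stronger inhibition and higher numbers for weaker inhibition:
Compound 1, `O=C(CSc1nnc(-c2ccncc2)o1)N/N=C/c1ccc([N+](=O)[O-])cc1`, gives 25800 nM.
Compound 2, `COc1cccc(/C=N/NC(=O)CSc2nnc(-c3ccncc3)o2)c1`, gives 16500 nM.
Compound 3, `O=C(CSc1nnc(-c2ccncc2)o1)N/N=C/c1ccccc1F`, gives 21500 nM.

All three share the same core and differ only in the aryl ring attached to the carbon that carries a double bond to nitrogen. On the numbers shown, compound 3 sits between the other two, but every step among them is within the scatter: a 1.2-fold lower number from compound 1 to compound 3 (0.08 log units; within the scatter), a 1.3-fold higher number from compound 2 to compound 3 (0.11 log units; within the scatter), and a 1.6-fold lower number from compound 1 to compound 2 (0.19 log units; within the scatter). Nothing here separates one aryl ring from another beyond the usual spread of repeat measurements.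

Compound 4, `O=C(CSc1nnc(-c2ccncc2)o1)N/N=C/c1ccccc1O`, has not yet been measured in this assay. It differs from compound 3 by one small change: hydroxy in place of fluoro on an aromatic carbon. The measured steps that bear on it are the three aryl-ring swaps above, each of which changed the number by less than the scatter. From that, the step from compound 3 to compound 4 is expected to be small as well, a 1.1-fold lower number from compound 3 to compound 4 (0.03 log units; within the scatter), with no clear direction. Compound 4 is therefore estimated at 20000 nM, most likely between 8000 nM and 50000 nM.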

Compound 4, half-maximal inhibitory concentration: 7380 nM
Compound 4: the middle estimate sits 2.7-fold (0.43 log units) above what was measured; the whole stated range lies above it.
By their numbers in this assay, from the lowest: compound 4; then compounds 2, 3 and 1 (each within the scatter of the next).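

In this assay, putting hydroxy in place of fluoro on this aromatic carbon, ortho to a large group, gives a 2.9-fold lower number from compound 3 to compound 4 (0.46 log units; beyond the scatter) and so moves the number by more than the usual spread of repeat measurements, which no swap among compound 1, compound 2 and compound 3 did. The aryl ring is therefore not a position where any change leaves the number alone: the 2-hydroxyphenyl ring also stands apart from the other two rings, with a 2.2-fold lower number from compound 2 to compound 4 (0.35 log units; beyond the scatter) and with a 3.5-fold lower number from compound 1 to compound 4 (0.54 log units; beyond the scatter) as the largest of the three new steps. The change adds a hydrogen-bond donor and a hydrogen-bond acceptor at this place, but no measurement shown here links either one to the lower number.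

The compounds shown leave open whether the hydroxy would give a similar step on another carbon of the same ring, so the effect of the group cannot yet be separated from the effect of its place. As far as these compounds go, it also remains open whether an amine or a carboxylic acid on this same aromatic carbon would match the hydroxy, or whether a methoxy there would lose the gain.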